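Amide-substituent variation on a shared core: antiproliferative readout

The source may hold more compounds than are shown below. What is called first, only, known or untested is meant among the compounds shown, and "the series" means these compounds.

Measured compounds:
compound 1, `C=CC(=O)Nc1cc2c(N3CCc4ccccc43)ncnc2cc1OC`: 5580 nM
compound 2, `C=CC(=O)Nc1cc2c(N3CCc4ccccc43)ncnc2cc1O[C@@H]1CCOC1`: 9320 nM
compound 3, `C/C=C/C(=O)Nc1cc2c(N3CCCc4ccccc43)ncnc2cc1OC`: 8190 nM

In a functional assay on A549 cells (Homo sapiens) for antiproliferative activity, read by MTT assay, with a stated time of 72 h (a lower number here means a stronger inhibitor, a higher number a weaker inhibitor), compound 1 gives the lowest of the three numbers, but its gap to compound 3 and to compound 2 lies within the scatter, so no order among the three can be read. Among the measured compounds shown here, the only single-place step is a 1.7-fold higher number from compound 1 to compound 2 (0.22 log units; within the scatter), which concerns the oxygen substituent on the aromatic ring and does not touch the amide end. Compound 3 differs from compound 1 in two places at once, so only its value stands beside that of compound 1, and the two values sit within the scatter of each other.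

Compound 4, `COc1cc2ncnc(N3CCc4ccccc43)c2cc1NC(=O)/C=C/CN1CCN(C)CC1`, is the next step from compound 1: 3-(4-methylpiperazin-1-yl)prop-1-en-1-yl in place of vinyl on a carbonyl carbon. For the measured compounds named here, no measured step bears on this change; the series gives no guidance for the amide side. The value of compound 4 is therefore estimated close to that of compound 1, with a 1.1-fold lower number from compound 1 to compound 4 (0.05 log units; within the scatter) as the expected step, and the estimate for compound 4 in this assay is 5000 nM (range 1500 nM to 16000 nM).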

Compound 4, half-maximal inhibitory concentration: 5360 nM
The estimate for compound 4 lay 1.1-fold (0.03 log units) below the measured number; the measured number falls inside the stated range.
By their numbers in this assay, from the lowest: compounds 4, 1, 3 and 2 (each within the scatter of the next).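

The amide end now has its first single-place step, with a 1.0-fold lower number from compound 1 to compound 4 (0.02 log units; within the scatter) in this assay when 3-(4-methylpiperazin-1-yl)prop-1-en-1-yl takes the place of vinyl on the carbonyl carbon. At this place, a substituent of 10 heavy atoms with a six-membered non-aromatic ring thus stands in for one of 2 heavy atoms, and no difference between the two compounds can be read. No supporting measurement bears on this result.

On these data alone, it remains open whether a morpholine or a dimethylamino group at the end of the same chain, or a longer chain carrying the 4-methylpiperazin-1-yl group, would also stay within the scatter of compound 1. As far as these compounds go, the same change on the oxolan-3-yl compound 2 is also open.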